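A few compounds are considered here, and "the series" means these few. Any claim that something is new, unique, unknown or untested is made for them only; others in the source may bear on it.

The measured compounds:
Compound 1, `CC1(C)S[C@@H]2/C(=C\C(=O)c3ccco3)C(=O)N2[C@H]1C(=O)OC(c1ccccc1)c1ccccc1`, gives 26000 nM in a functional assay on A-375 cells (Homo sapiens) for cytotoxicity, read by MTT assay, with a stated time of 48 h; a higher number here means a weaker inhibitor, a lower number a stronger inhibitor.
Compound 2, `CC1(C)[C@H](C(=O)OC(c2ccccc2)c2ccccc2)N2C(=O)/C(=C/C(=O)c3ccc([N+](=O)[O-])cc3)[C@H]2[S+]1[O-]`, gives 48200 nM in this assay.
Compound 3, `CCOC(=O)/C=C1/C(=O)N2[C@@H]1SC(C)(C)[C@@H]2C(=O)OC(c1ccccc1)c1ccccc1`, gives 7000 nM in this assay.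

Compound 1 holds the second highest number of the three. Compound 2 sits nearest to it, within the scatter, so no order between these two can be read. Compound 3 lies furthest, with a 3.7-fold lower number from compound 1 to compound 3 (0.57 log units; beyond the scatter).

Compound 4, `CC1(C)S[C@@H]2/C(=C\C(=O)c3cc(F)cc(F)c3)C(=O)N2[C@H]1C(=O)OC(c1ccccc1)c1ccccc1`, has not been measured. It differs from compound 1 in one place: 3,5-difluorophenyl in place of furan-2-yl on a carbonyl carbon.

For the measured compounds named here, only one measured step touches this carbonyl carbon, the one from compound 1 to compound 3, and it exchanges the furan-2-yl for ethoxy rather than for another aromatic ring, so it bears on the change only loosely. Compound 2 carries a nitrophenyl on the corresponding carbonyl but differs from compound 1 elsewhere as well, so its value cannot be set against compound 1 as a single step. Going by the values given here, with no direct precedent, the expectation for compound 4 is a step no larger than the scatter, in either direction. Compound 4 is therefore estimated at 20000 nM, with a range from 7000 nM to 60000 nM, which would mean an expected 1.3-fold lower number from compound 1 to compound 4 (0.11 log units; within the scatter).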

Compound 4, half-maximal inhibitory concentration: 19100 nM
The estimate for compound 4 lay 1.0-fold (0.02 log units) above the measured number; low and high end bracket the measured number.
By their numbers in this assay, from the lowest: compound 3; then compounds 4, 1 and 2 (each within the scatter of the next, the first and the last beyond it).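

In this assay, the exchange of one aromatic ring for another on this carbonyl carbon gives a 1.4-fold lower number from compound 1 to compound 4 (0.13 log units; within the scatter) and so does not separate furan-2-yl from 3,5-difluorophenyl, although the entering group has 8 heavy atoms in place of 5 and 0 hydrogen-bond acceptors in place of 1. The ethoxy group now stands apart from a second ring as well: the earlier 3.7-fold lower number from compound 1 to compound 3 (0.57 log units; beyond the scatter) is joined by a 2.7-fold higher number from compound 3 to compound 4 (0.44 log units; beyond the scatter) as a further modest step, so in these three compounds the ethoxy compound has the lowest number and neither ring matches it. Nothing available explains either step, and no measurement of any property of these groups bears on them.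

Compound 2 differs from the others in more than one place, so its steps cannot be read. From the compounds shown here alone, it remains open whether an unsubstituted phenyl, an amine or a longer alkoxy chain such as butoxy on this carbonyl carbon would fall with the two rings or with ethoxy, and so whether the ethoxy result reflects that one group alone.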